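The source may report more compounds than this note shows. Statements on the series, on what has been measured and on what is new or still open speak of the compounds shown alone.

In a functional assay on NCI-H460 cells (Homo sapiens) for cytotoxicity, read by MTT assay, with a stated time of 96 h (a higher number here means a weaker inhibitor, a lower number a stronger inhibitor), compound 3 `COc1ncc(-c2cc(OC3CCOCC3)c3nc(N)nc(C)c3c2)cc1NS(=O)(=O)C1CC1` gives 930 nM. That number lies within the scatter of the two other measured compounds: compound 2 `COc1ncc(-c2cc(OC3CCOCC3)c3nc(N)nc(C)c3c2)cc1NS(C)(=O)=O` gives 860 nM, and compound 1 `COc1ncc(-c2cc(OC3CCN(C)CC3)c3nc(N)nc(C)c3c2)cc1NS(=O)(=O)c1ccc(F)cc1F` gives 660 nM.

Compound 4 `COc1ccc(-c2cc(OC3CCOCC3)c3nc(N)nc(C)c3c2)cn1` has no number yet. It differs from compound 3 by a single change: hydrogen in place of (cyclopropylsulfonyl)amino on an aromatic carbon. In words, this is hydrogen in place of (cyclopropylsulfonyl)amino on an aromatic carbon.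

Going by the values given here, one measured step touches this group. Cyclopropyl in place of methyl on the sulfonyl sulfur gave a 1.1-fold higher number from compound 2 to compound 3 (0.03 log units; within the scatter). That step alters only the outer end of the group, however, and says little about losing all of it. Among the compounds with values here, all three measured compounds keep a sulfonylamino group, so the data contain no example without one, and the size of the step remains uncertain.

The numbers stay close together only among compounds that have this group, so a move beyond the scatter towards a weaker inhibitor is expected, as a judgement and not a measured trend. The estimated change is a 5.4-fold higher number from compound 3 to compound 4 (0.73 log units; beyond the scatter). For compound 4 the expected value is 5000 nM, with an estimated range of 1500 nM to 20000 nM.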

Compound 4, half-maximal inhibitory concentration: 980 nM
Estimate against measurement, compound 4: 5.1-fold (0.71 log units) above; the whole stated range lies above it.
By their numbers in this assay, from the lowest: compounds 1, 2, 3 and 4 (each within the scatter of the next).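

The new result concerns one assay (this assay). On the aromatic carbon ortho to a methoxy group, the whole (cyclopropylsulfonyl)amino group can give way to hydrogen with a step that stays within the scatter (a 1.1-fold higher number from compound 3 to compound 4 (0.02 log units; within the scatter)). The methanesulfonamido group gives the same reading when hydrogen takes its place (a 1.1-fold higher number from compound 2 to compound 4 (0.06 log units; within the scatter)), so unlike the earlier step, which varied only the outer end of the group, these two steps show that for compound 2, compound 3 and compound 4 this assay does not separate a sulfonylamino group at this position from none at all. No supporting measurement is available to explain why the number holds.

As far as these compounds go, it stays open whether other groups on this aromatic carbon, such as an amine, a hydroxyl or a carboxylic acid, would also stay within the scatter or would move the number beyond it. From the compounds shown here alone, it also stays open whether the same loss would read alike in compound 1, which differs from the other compounds in more than one place.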